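A few compounds are considered here, and "the series" means these few. Any claim that something is new, unique, unknown or untested is made for them only; others in the source may bear on it.

Of the compounds shown here, three built on the same core have been measured for how strongly they slow the growth of a breast-cancer cell line, in a functional assay on MCF7 cells (Homo sapiens) for antiproliferative activity, read by CCK-8 assay, with a stated time of 48 h; on this read-out lower numbers stand for stronger inhibition and higher numbers for weaker inhibition. Compound 1 `O=c1c2ccccc2[se]n1-c1nnc(-c2ccc(F)cc2)s1` gives 61500 nM, the highest of the three numbers. Compound 2 `O=c1c2ccccc2[se]n1-c1nnc(-c2cc([N+](=O)[O-])cc([N+](=O)[O-])c2)s1` gives 37800 nM, and the gap between these two lies within the usual scatter of repeated measurements, so they cannot be told apart on this read-out. Compound 3 `COc1ccccc1-c1nnc(-n2[se]c3ccccc3c2=O)s1` gives 3920 nM, and here the gap to compound 1 is far beyond the scatter, so compound 3 is clearly the stronger inhibitor of the pair.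

Compound 4 `Cc1ccc(-c2nnc(-n3[se]c4ccccc4c3=O)s2)cc1` has not yet been measured. It differs from compound 1 in one place: methyl in place of fluoro on an aromatic carbon. Among the measured compounds shown here, no measured pair in this set shows the effect of that exact exchange, so there is no step to lean on. The expectation for compound 4 is a small step, a 1.5-fold lower number from compound 1 to compound 4 (0.19 log units; within the scatter), most likely not beyond the scatter in either direction. On that basis compound 4 is estimated at 40000 nM in this assay, with a plausible range from 12000 nM to 130000 nM.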

Compound 4, half-maximal inhibitory concentration: 18700 nM
The estimate for compound 4 lay 2.1-fold (0.33 log units) above the measured number; low and high end bracket the measured number.
By their numbers in this assay, from the lowest: compound 3; then compound 4; then compounds 2 and 1 (each within the scatter of the next).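

Putting methyl in place of fluoro on an aromatic carbon of the six-membered aromatic ring, para to a large group, gives a 3.3-fold lower number from compound 1 to compound 4 (0.52 log units; beyond the scatter) in this assay. Among the compounds shown here, this is the first pair in the set that differs in one place only, so it is the first direct reading of this position: the number moves beyond the usual scatter, though only modestly, with no ring, hydrogen-bond donor, hydrogen-bond acceptor or net charge entering or leaving. Nothing in the data at hand explains why the number is lower with methyl than with fluoro.

Going by these compounds, a single step at a single position cannot show a trend, so it remains open whether a chloro group, an amine, a carboxylic acid or a longer chain such as ethyl at the same place would take the number further down or back up. Also open, on these data alone, is whether the same exchange of fluoro for methyl at another place on this ring would give a step of similar size, or any step beyond the scatter at all.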